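The compounds below may be only part of what the source reports. "The series", "measured", "known", "first", "only" and "open" are said of these compounds alone.

In a functional assay on SW480 cells (Homo sapiens) for antiproliferative activity, read by sulforhodamine B assay, with a stated time of 48 h (a lower number here means a stronger inhibitor, a higher number a weaker inhibitor), compound 1 `COc1ccc(/C=C/C(=O)c2ccccc2-c2ccc(F)cc2)cc1` gives 61 nM, compound 2 `COc1ccc(/C=C/C(=O)c2ccccc2-c2ccc(F)cc2)cc1B(O)O` gives 41 nM, and compound 3 `Cc1ccc(/C=C/C(=O)c2ccccc2-c2ccc(F)cc2)o1` gives 23000 nM, the highest and so the weakest of the three. Compound 4 `O=C(/C=C/c1cccs1)c1ccccc1-c1ccc(F)cc1` is still unmeasured. It has thiophen-2-yl in place of 5-methylfuran-2-yl on a double-bonded chain carbon bound to a double-bonded chain carbon. That same place produced a large step, a 380-fold higher number from compound 1 to compound 3 (2.58 log units; beyond the scatter), when 5-methylfuran-2-yl replaced 4-methoxyphenyl. The other step, a 1.5-fold lower number from compound 1 to compound 2 (0.17 log units; within the scatter), was made on the 4-methoxyphenyl group, which compound 3 and compound 4 lack, so it says little here. Among the compounds with values here, no measured step exchanges one five-membered aromatic ring for another, so the estimate is uncertain. In this assay the expected change is only a 1.5-fold lower number from compound 3 to compound 4 (0.19 log units; within the scatter), nothing beyond the scatter. For compound 4 the estimated value is 15000 nM, with an expected range from 3000 nM to 50000 nM.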

Compound 4, half-maximal inhibitory concentration: 16000 nM
Compound 4: middle estimate off by 1.1-fold (0.03 log units), on the low side; the range from low to high includes it.
By their numbers in this assay, from the lowest: compounds 2 and 1 (each within the scatter of the next); then compounds 4 and 3 (each within the scatter of the next).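

In this assay exchanging one five-membered aromatic ring for another at this place changes little (a 1.4-fold lower number from compound 3 to compound 4 (0.16 log units; within the scatter)). Replacing 4-methoxyphenyl with thiophen-2-yl gives a large step (a 260-fold higher number from compound 1 to compound 4 (2.42 log units; beyond the scatter)), so the large loss is not confined to 5-methylfuran-2-yl but appears with both five-membered rings shown. No measured evidence here explains that loss. The compounds shown leave open whether a six-membered aromatic ring carrying an amine or a carboxylic acid in place of the methoxy group would keep the activity of compound 1.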